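Butyl for isopropyl at the limit of the assay

A few compounds are considered here, and "the series" means these few. Any claim that something is new, unique, unknown or untested is made for them only; others in the source may bear on it.

Working notes on compound 1 (`COc1cc(-c2nccn2C)cc(OC)c1OC`), compound 2 (`COc1cc(-c2nccn2C(C)C)cc(OC)c1OC`) and compound 3 (`CCCCn1ccnc1-c1cc(OC)c(OC)c(OC)c1`), which share one core and differ in the group on an aromatic nitrogen.

In a functional assay on MDA-MB-231 cells (Homo sapiens) for antiproliferative activity, read by MTT assay, with a stated time of 72 h (a lower number here means a stronger inhibitor, a higher number a weaker inhibitor), compound 1 gives > 100000 nM, which is a limit and not a number. Compound 2 gives > 100000 nM, which is also a limit. Compound 2 therefore has no readable position in the series, and the evidence so far is the limit of > 100000 nM in this assay, at which 2 of the 2 values shown sit.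

The next change is butyl in place of isopropyl on an aromatic nitrogen. In words, this is butyl in place of isopropyl on an aromatic nitrogen, next to the ring atom that bears a large group.

Among the compounds with values here, one measured step bears on it: a step that the two limits leave unreadable from compound 1 to compound 2. That step is also made on an aromatic nitrogen, but it gives no size to carry over. No shift beyond the scatter is expected in this assay, and no direction can be assigned.

The expected change for compound 3 is a number no higher from compound 2 to compound 3 (the limit leaves the size open), an estimate that stays within the scatter. The estimate for compound 3 is 100000 nM, with an expected range of 40000 nM to 200000 nM.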

Compound 3, half-maximal inhibitory concentration: 70400 nM
The estimate for compound 3 lay 1.4-fold (0.15 log units) above the measured number, within the range that was stated.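

In this assay, within the data shown here, compound 3 is the only one of the three compounds with a number rather than a limit, so the group on the aromatic nitrogen now has one readable value. Butyl in place of isopropyl gives an at least 1.4-fold lower number from compound 2 to compound 3 (0.15 log units; that floor lies within the scatter), and propyl in place of hydrogen on a saturated chain carbon bound to an aromatic nitrogen gives an at least 1.4-fold lower number from compound 1 to compound 3 (0.15 log units; that floor lies within the scatter); both sizes are floors, so neither step shows a change beyond the scatter, although the true sizes could be larger. Butyl thus brings a measurable number at this position, but the series remains at the edge of what the assay can read: the limit of > 100000 nM in this assay, at which 2 of the 3 values shown sit.

The limits for compound 1 and compound 2 leave open whether butyl truly differs from methyl or isopropyl in this assay. Going by these compounds, it also remains open how a longer chain such as hexyl, or a chain ending in an amine or a carboxylic acid, would read on this nitrogen, and whether chain length carries any trend at all.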